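The compounds below may be only part of what the source reports. "The series", "measured", "known", "first", "only" and "open" are said of these compounds alone.

Three members of the series share one core: compound 1 `CCCCCCSc1n[nH]c(-n2[se]c3ccccc3c2=O)n1`, compound 2 `Cc1ccc(CSc2n[nH]c(-n3[se]c4ccccc4c3=O)n2)cc1` and compound 3 `CC(C)Sc1n[nH]c(-n2[se]c3ccccc3c2=O)n1`, differing in the group on the sulfur. In a functional assay on A549 cells (Homo sapiens) for antiproliferative activity, read by CCK-8 assay, with a stated time of 48 h (a higher number here means a weaker inhibitor, a lower number a stronger inhibitor), compound 1 gives 20300 nM and compound 3 gives 36600 nM; these two values lie within the scatter of each other. For compound 2 the result is a limit of the assay, > 50000 nM, as noted in the limit of > 50000 nM in this assay, at which 1 of the 3 values shown sits. Compound 4 `CCCSc1n[nH]c(-n2[se]c3ccccc3c2=O)n1` differs from compound 3 by propyl in place of isopropyl on a sulfur. The closest measured step, a 1.8-fold higher number from compound 1 to compound 3 (0.26 log units; within the scatter), stayed within the scatter, whereas an at least 2.4-fold higher number from compound 1 to compound 2 (0.39 log units; beyond the scatter) went beyond it. For compound 4 the expected step is therefore small, a 1.2-fold lower number from compound 3 to compound 4 (0.09 log units; within the scatter), with no shift beyond the scatter. Compound 4 is estimated at 30000 nM, within 14000 nM to 60000 nM.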

Compound 4, half-maximal inhibitory concentration: 45500 nM
For compound 4 the middle estimate is 1.5-fold (0.18 log units) below the measured one; measured number inside the range.
By their numbers in this assay, from the lowest: compounds 1, 3 and 4 (each within the scatter of the next, the first and the last beyond it). At a limit, above all of these: compound 2.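

In this assay, propyl in place of isopropyl on a sulfur gives a 1.2-fold higher number from compound 3 to compound 4 (0.09 log units; within the scatter). Going from the hexyl to the propyl chain gives a 2.2-fold higher number from compound 1 to compound 4 (0.35 log units; beyond the scatter), the first step beyond the scatter between two alkyl groups on the sulfur, although compound 3 lies within the scatter of both compounds. The remaining step, an at least 1.0-fold lower number from compound 2 to compound 4 (0.04 log units; that floor lies within the scatter), rests on a limit of the assay, so it cannot be read. Compound 2 stands at a limit of the assay: the limit of > 50000 nM in this assay, at which 1 of the 4 values shown sits.

From the compounds shown here alone, whether a chain longer than hexyl lowers the number further stays open. So does the effect of a chain carrying an amine or a carboxylic acid.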